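A few compounds are considered here, and "the series" means these few. Any claim that something is new, unique, unknown or untested is made for them only; others in the source may bear on it.

The study concerns four compounds built on two related cores and tested in an ADME assay on MRC5 cells (Homo sapiens) for antiproliferative activity, read by MTT assay, with a stated time of 48 h; a higher number here means a weaker inhibitor, a lower number a stronger inhibitor. Compound 1 `Cc1oc2c3c(ccc2c(=O)c1C)OC[C@H]1[C@@H]3C2=C(CC(C)(C)CC2=O)OC1(C)C` carries a methyl group at the position of interest. In this assay compound 1 gives > 100000 nM, which is a limit of the assay and not a number. Compound 2 `Cc1oc2c3c(ccc2c(=O)c1-c1ccccc1)OC[C@H]1[C@@H]3C2=C(CC(C)(C)CC2=O)OC1(C)C` differs from compound 1 by one change, (phenyl in place of methyl on an aromatic carbon). In this assay compound 2 gives > 100000 nM, again a limit rather than a number. The step that the two limits leave unreadable from compound 1 to compound 2 therefore cannot be read, since both ends sit at the same boundary.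

Compound 3 `Cc1nn(-c2ccccc2)c2c1[C@@H]1c3c(ccc4c(=O)c(C)c(C)oc34)OC[C@@H]1C(C)(C)O2` rests on a second core; the difference between the two cores is not broken down here. In this assay compound 3 gives > 100000 nM, which is a limit and not a number. Compound 4 `Cc1nn(-c2ccccc2)c2c1[C@@H]1c3c(ccc4c(=O)c(-c5ccccc5)c(C)oc34)OC[C@@H]1C(C)(C)O2` is not yet measured and differs from compound 3 by phenyl in place of methyl on an aromatic carbon, the same change that leads from compound 1 to compound 2.

Going by the values given here, what can be expected of compound 4 rests on a single observation, (the limit of > 100000 nM in this assay, at which 3 of the 3 values shown sit), which places every value so far at the boundary of the assay. Among the compounds with values here, the step from compound 3 to compound 4 is therefore estimated as a number no higher from compound 3 to compound 4 (the limit leaves the size open), with no measured step to argue for a larger move. Compound 4 is accordingly expected to give about 100000 nM in this assay, within a range from 60000 nM to 150000 nM, and most likely as a limit once more.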

Compound 4, half-maximal inhibitory concentration: > 100000 nM
Compound 4: no number, only a limit; the forecaster's own chance of this, stated with the estimate: 85%; the middle value sits exactly at the limit.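

In this assay compound 4 gives > 100000 nM, which is a limit and not a number. Compound 3 also stands at a limit, so no step can be read from compound 3 to compound 4. The compounds shown leave open how strongly any of them acts in this assay, and what phenyl in place of methyl on an aromatic carbon does to that value.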